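The source may report more compounds than this note shows. Statements on the series, on what has been measured and on what is new or still open speak of the compounds shown alone.

Measured compounds:
compound 1 `CC(=O)Nc1cccc(-c2cn(Cc3cc(C(=O)O)cc(-c4ccccc4C(=O)O)c3)nn2)c1` gives 96200 nM
compound 2 `CC(C(=O)O)c1ccc(C(=O)c2cccc(-c3occc3C(=O)O)c2)s1` gives 75700 nM
compound 3 `Nc1ccc(-c2cn(Cc3cc(C(=O)O)cc(-c4cccc(C(=O)O)c4)c3)nn2)cc1` gives 32900 nM

In an assay on cells for inhibition of ubiquitin carboxyl-terminal hydrolase isozyme L5 (Homo sapiens), read by fluorescence, with a stated time of 30 min (a higher number here means a weaker inhibitor, a lower number a stronger inhibitor), compound 1 stands at the highest of the three numbers. Compound 2 lies within the scatter of compound 1, so no order between the two can be read. Compound 3, which carries a free amino group, lies beyond the scatter of compound 1, at a lower number.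

Compound 4 `Nc1cccc(-c2cn(Cc3cc(C(=O)O)cc(-c4ccccc4C(=O)O)c3)nn2)c1` differs from compound 1 by hydrogen in place of acetyl on a nitrogen on an aromatic ring. Going by the values given here, no measured pair shows this change on its own, so its size is open. The step from compound 1 to compound 4 is expected as a 1.6-fold lower number from compound 1 to compound 4 (0.21 log units; within the scatter), toward a lower number, of a size that may still sit within the scatter. Compound 4 is expected to give 60000 nM, between 20000 nM and 150000 nM in this assay.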

Compound 4, half-maximal inhibitory concentration: 72600 nM
Beside the measured number, compound 4's estimate is 1.2-fold (0.08 log units) below it; the range from low to high includes it.
By their numbers in this assay, from the lowest: compound 3; then compounds 4, 2 and 1 (each within the scatter of the next).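

In this assay, hydrogen in place of acetyl on a nitrogen on an aromatic ring gives a 1.3-fold lower number from compound 1 to compound 4 (0.12 log units; within the scatter). This is the first pair shown that differs in one place, and it puts 3-acetamidophenyl and 3-aminophenyl within the scatter of each other, so neither group can be placed ahead of the other at this position. No measurement at hand accounts for this result. The compounds shown leave open whether a methyl group, a longer acyl chain or a methanesulfonyl group on this nitrogen would give a step beyond the scatter.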